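This account rests on a few compounds, and the source may have more. Where it says the series, first, only, none or still open, it means among the compounds named here.

Compound 1 `CC(C)(C)[C@@H](O)C(=O)N1CSC[C@H]1C(=O)NCc1cc(Cl)ccc1-n1cnnn1` gives 120 mL.min-1.g-1 in an ADME assay on liver for metabolic stability, with Liver microsome (Homo sapiens) as the target, read by LC-MS, using microsomes; a higher number here means faster removal of the compound, a lower number slower removal.
Compound 2 `O=C(NCc1cc(Cl)ccc1-n1cnnn1)[C@@H]1[C@H]2C[C@H]2CN1C(=O)[C@H](O)c1ccccc1` gives 61 mL.min-1.g-1 in this assay.
Compound 3 `O=C(NCc1cc(Cl)ccc1-n1cnnn1)[C@@H]1[C@@H]2C[C@@H]2CN1C(=O)[C@H](O)c1ccccc1` gives only a limit, < 15 mL.min-1.g-1, in this assay.

Compound 3 stands at the bottom of what has been measured here: its value is a limit of the assay and not a number, so its clearance is known only to lie under that mark (the limit of < 15 mL.min-1.g-1 in this assay, at which 1 of the 3 values shown sits). For the measured compounds named here, the one measured step that reaches it, an at least 4.0-fold lower number from compound 2 to compound 3 (0.60 log units; beyond the scatter), is beyond the scatter, and it arises from nothing more than the fact that compounds 2 and 3 differ only in the configuration as drawn: the two compounds share every atom and bond. Going by the values given here, compound 1 carries a different ring in its core and sits far higher, but no single-change step links it to compound 3.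

Compound 4 `COC(C)(C)[C@@H](O)C(=O)N1C[C@H]2C[C@H]2[C@H]1C(=O)NCc1cc(Cl)ccc1-n1cnnn1` is made from compound 3 by the change (1-methoxy-1-methylethyl in place of phenyl on a saturated chain carbon bound to a carbonyl carbon and an oxygen on a saturated carbon). Among the compounds with values here, no measured step here swaps a phenyl for a chain group of this kind, so there is no direct guide to the size of the move in this assay. Given that compound 3 is only a limit, the expected step is an at least 1.4-fold higher number from compound 3 to compound 4 (0.16 log units; that floor lies within the scatter), that is, an increase that brings compound 4 into measurable territory yet keeps it slow. Compound 4 is estimated at 22 mL.min-1.g-1, within 7 mL.min-1.g-1 to 65 mL.min-1.g-1.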

Compound 4, intrinsic clearance in microsomes: 23 mL.min-1.g-1
Beside the measured number, compound 4's estimate is 1.0-fold (0.02 log units) below it; the range from low to high includes it.
By their numbers in this assay, from the lowest: compound 4; then compounds 2 and 1 (each within the scatter of the next). At a limit, below all of these: compound 3.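

In this assay, putting 1-methoxy-1-methylethyl in place of phenyl on this saturated chain carbon gives an at least 1.5-fold higher number from compound 3 to compound 4 (0.18 log units; that floor lies within the scatter), the only step shown that alters this group, as compounds 2 and 3 differ only in configuration. That floor lies within the scatter, so the step does not establish that the exchange speeds removal at all; it shows only that this position accepts a group with no ring and that the result can be read as a number. The true size of the step stays hidden because compound 3 stands at a limit of the assay and not at a number: the limit of < 15 mL.min-1.g-1 in this assay, at which 1 of the 4 values shown sits.

From the compounds shown here alone, the role of the oxygen in the new group remains open, and a tert-butyl group on the core of compound 4 would separate it from the effect of losing the phenyl ring, since compound 1 carries a different core and cannot answer this. Also open, going by these compounds, is how a cyclohexyl ring or a longer chain at this position would read, and whether any such exchange would move the number in the same direction in the configuration of compound 2.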